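A few compounds are considered here, and "the series" means these few. Any claim that something is new, unique, unknown or untested is made for them only; others in the source may bear on it.

Measured so far:
- Compound 1 `O=C(c1ccncc1)n1c(-c2cn(-c3ccccc3)nc2-c2ccc(F)cc2)nc2ccccc21`: 151000 nM
- Compound 2 `Cc1ccc(-c2nn(-c3ccccc3)cc2-c2nc3ccccc3n2C(=O)c2ccccc2)cc1`: 204000 nM
- Compound 3 `Cc1ccc(-c2nn(-c3ccccc3)cc2-c2nc3ccccc3n2C(=O)c2ccc(Cl)cc2)cc1`: 216000 nM

These three compounds were tested in an ADME assay on HEK-293T cells (Homo sapiens) for cytotoxicity, read by MTT assay, with a stated time of 24 h; a higher number here means that more compound is tolerated, a lower number that less compound is tolerated. Compound 3 stands within the usual scatter of both other compounds: its step from compound 2, a 1.1-fold higher number from compound 2 to compound 3 (0.02 log units; within the scatter), is too small to count as a real change, and its gap to compound 1 is also within the scatter. Compound 1 and compound 3 differ in two places, so their values only show that a pyridin-4-yl carbonyl is tolerated in this series at about the same level.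

The next compound, compound 4 `Cc1ccc(-c2nn(-c3ccccc3)cc2-c2nc3ccccc3n2C(=O)c2ccncc2)cc1`, is not yet measured. It is compound 3 with one change: pyridin-4-yl in place of 4-chlorophenyl on a carbonyl carbon. Within the data shown here, no measured step covers this exact exchange. The only one-place step shown, from compound 2 to compound 3, lies within the scatter, and compound 1 carries the same pyridin-4-yl carbonyl without standing apart from the others. The expected step from compound 3 to compound 4 in this assay is therefore a 1.2-fold lower number from compound 3 to compound 4 (0.08 log units; within the scatter), a change not beyond the scatter. Compound 4 is estimated at 180000 nM, in a range from 110000 nM to 300000 nM.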

Compound 4, half-maximal cytotoxic concentration: 154000 nM
Compound 4: middle estimate off by 1.2-fold (0.07 log units), on the high side, and the stated range covers the measured number.
By their numbers in this assay, from the lowest: compounds 1, 4, 2 and 3 (each within the scatter of the next).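

In this assay the move from the (4-chlorophenyl)carbonyl to the (pyridin-4-yl)carbonyl gives a 1.4-fold lower number from compound 3 to compound 4 (0.15 log units; within the scatter) and the matching move from phenyl gives a 1.3-fold lower number from compound 2 to compound 4 (0.12 log units; within the scatter) so on this carbonyl carbon, a ring with one ring nitrogen and one hydrogen-bond acceptor stays within the scatter of both carbon-only rings. With the pyridin-4-yl carbonyl held fixed, a second place can also be read: methyl in place of fluoro on an aromatic carbon gives a 1.0-fold higher number from compound 1 to compound 4 (0.01 log units; within the scatter) and this step is within the scatter too. No measurement shown here bears on why these steps are so small.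

Going by these compounds, it remains open whether a group on this carbonyl carbon that is not an aromatic ring, such as an amine or a longer chain, would also stay within the scatter. On these data alone, it is equally open whether a carboxylic acid on the aromatic carbon that carries the methyl or fluoro would move the number beyond it.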